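Replacing the benzyl group of compound 3: working notes

This account rests on a few compounds, and the source may have more. Where it says the series, first, only, none or still open, it means among the compounds named here.

Measured in a functional assay on the whole organism with Rattus norvegicus as the target; a lower number here means that less compound is needed, a higher number that more compound is needed for the effect:
compound 1 `Nc1nc2ccc(OCC(F)(F)F)cc2s1`: 6.5 mg/kg
compound 2 `Nc1nc2ccc(OC(F)(F)C(F)(F)F)cc2s1`: 2.5 mg/kg
compound 3 `N=c1sc2cc(OC(F)(F)F)ccc2n1Cc1ccccc1`: > 10 mg/kg

Compound 3 stands at > 10 mg/kg, which is a limit of this assay and not a number. Only compound 1 at 6.5 mg/kg and compound 2 at 2.5 mg/kg have numerical values.

Compound 4 `CNS(=O)(=O)CCn1c(=N)sc2cc(OC(F)(F)F)ccc21` keeps the core of compound 3 and carries 2-(methylsulfamoyl)ethyl in place of benzyl, which amounts to (methylsulfamoyl)methyl in place of phenyl on a saturated chain carbon bound to an aromatic nitrogen. Going by the values given here, no measured pair isolates this change, so the expectation is loose. A moderate move towards a lower dose is expected in this assay, although a result at the limit remains possible. The expected change is an at least 2.5-fold lower number from compound 3 to compound 4 (0.39 log units; beyond the scatter), and it is only approximate since it starts from a limit. The expectation leans on the numerical range set by compound 1 at 6.5 mg/kg and compound 2 at 2.5 mg/kg. For compound 4 the estimate is 4 mg/kg, with an expected range from 1.2 mg/kg to 14 mg/kg.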

Compound 4, dose for half-maximal effect: 4 mg/kg
Compound 4: the middle estimate sits on the measured number at the digits printed, and the stated range covers the measured number.
By their numbers in this assay, from the lowest: compounds 2, 4 and 1 (each within the scatter of the next, the first and the last beyond it). At a limit, above all of these: compound 3.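

In this assay, (methylsulfamoyl)methyl in place of phenyl on a saturated chain carbon bound to an aromatic nitrogen brings an at least 2.5-fold lower number from compound 3 to compound 4 (0.39 log units; beyond the scatter). The value of compound 3, > 10 mg/kg, is a limit of the assay and not a number, so the step has no upper end. Compound 4, at 4 mg/kg, shows that a numerical dose at this place does not need an aromatic ring on the chain.

The compounds shown do not separate the loss of the phenyl ring from the arrival of the methylsulfamoyl group, so it stays open which of the two carries the step. Also open, going by these compounds, is how a plain propyl chain, a carboxylic acid or an unsubstituted sulfamoyl group at this place would read in this assay.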